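Ethyl to methyl on the piperazine: a binding estimate

This account rests on a few compounds, and the source may have more. Where it says the series, first, only, none or still open, it means among the compounds named here.

- compound 1 `CNc1nccc(N2CC[C@H](NC(=O)Nc3ccc(CN4CCC4)c(C(F)(F)F)c3)C2)n1` gives 89.2%
- compound 2 `CCN1CCN(Cc2ccc(NC(=O)N[C@H]3CCN(c4ccnc(NC)n4)C3)cc2C(F)(F)F)CC1` gives 84.2%

These two values from an ADME assay on a cell-free system (plasma, Rattus norvegicus) for protein binding, lie within the scatter of each other, so compound 2 stands level with compound 1. Compound 3 `CNc1nccc(N2CC[C@H](NC(=O)Nc3ccc(CN4CCN(C)CC4)c(C(F)(F)F)c3)C2)n1` differs from compound 2 by hydrogen in place of methyl on a saturated chain carbon bound to an amine nitrogen in a ring, which turns 4-ethylpiperazin-1-yl into 4-methylpiperazin-1-yl. Within the data shown here, the only measured step changed this same group and gave a 1.5-fold higher unbound fraction from compound 1 to compound 2 (0.17 log units; within the scatter), so no step beyond the scatter is expected in this assay here. The estimated step is a 1.1-fold higher unbound fraction from compound 2 to compound 3 (0.06 log units; within the scatter), which is small. For compound 3 the estimated value is 82%, with an expected range from 72% to 90% in this measurement.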

Compound 3, plasma protein binding: 85.1%
Estimate against measurement, compound 3: 1.2-fold (0.08 log units) (unbound fraction) above; measured number inside the range.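

Shortening ethyl to methyl gives a 1.1-fold lower unbound fraction from compound 2 to compound 3 (0.03 log units; within the scatter) in this assay and so does not move binding beyond the usual scatter. Replacing azetidin-1-yl with 4-methylpiperazin-1-yl gives a 1.4-fold higher unbound fraction from compound 1 to compound 3 (0.14 log units; within the scatter) as well, so the three compounds stand level in this measurement, whichever of these groups they carry. No measured evidence here offers a reason for these values.

On these data alone, whether a carboxylic acid or a longer chain in place of the ethyl or methyl would move binding beyond the scatter stays open. As far as these compounds go, the three compounds also share the rest of the core, so changes elsewhere remain untested here.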